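The source may report more compounds than this note shows. Statements on the series, on what has been measured and on what is new or still open speak of the compounds shown alone.

In an ADME assay on HEK-293T cells (Homo sapiens) for cytotoxicity, read by CCK-8 assay, with a stated time of 48 h (a higher number here means a weaker inhibitor, a lower number a stronger inhibitor), compound 2 (`O=S(=O)(NCCNC(=S)Nc1cccc(Cl)c1)c1ccc(-c2ccccc2OCc2ccccc2)s1`) gives 10200 nM and compound 3 (`O=[N+]([O-])c1cccc(NC(=S)NCCNS(=O)(=O)c2ccc(-c3ccccc3OCc3ccccc3)s2)c1`) gives 18300 nM, so these two stand within the scatter of each other. Compound 1 (`O=C(NCCNS(=O)(=O)c1ccc(-c2ccccc2OCc2cccc(O)c2)s1)Nc1cc(Cl)cc(Cl)c1`) gives > 20000 nM, which is a limit of the assay and not a number.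

Compound 4 (`O=[N+]([O-])c1cccc(NC(=S)NCCNS(=O)(=O)c2ccc(-c3ccccc3OCc3cccc(O)c3)s2)c1`) comes from compound 3 by one change, hydroxy in place of hydrogen on an aromatic carbon, which turns benzyl into 3-hydroxybenzyl: hydroxy in place of hydrogen on an aromatic carbon. For the measured compounds named here, no measured step tests this change directly. Going by the values given here, the only measured step is a 1.8-fold higher number from compound 2 to compound 3 (0.25 log units; within the scatter), and it concerns nitro in place of chloro at another place, so it bears on the new change only loosely. Compound 1 also carries the 3-hydroxybenzyl group, but it differs from compound 3 elsewhere as well, so its limit cannot be tied to the hydroxy.

Starting from compound 3 at 18300 nM, no shift beyond the scatter is expected in this assay, and the expected step is a 1.1-fold lower number from compound 3 to compound 4 (0.03 log units; within the scatter). Compound 4 is estimated at 17000 nM, with an expected range of 9000 nM to 32000 nM.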

Compound 4, half-maximal inhibitory concentration: 13800 nM
Compound 4: the middle estimate sits 1.2-fold (0.09 log units) above what was measured; the range from low to high includes it.
By their numbers in this assay, from the lowest: compounds 2, 4 and 3 (each within the scatter of the next). At a limit, above all of these: compound 1.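

In this assay, for the compounds shown here, the change from benzyl to 3-hydroxybenzyl gives a 1.3-fold lower number from compound 3 to compound 4 (0.12 log units; within the scatter), so hydroxy on this aromatic carbon, meta to a large group, leaves the number within the scatter, a comparison that no earlier pair offered. Compound 1, which carries the same 3-hydroxybenzyl group, stands at a limit of the assay and not at a number: the limit of > 20000 nM in this assay, at which 1 of the 4 values shown sits. With the hydroxy held constant, the exchange of the group on the amine nitrogen gives an at least 1.4-fold lower number from compound 1 to compound 4 (0.16 log units; that floor lies within the scatter), so only a floor can be read from this step.

From the compounds shown here alone, whether a methoxy or an amine in place of the hydroxy would move the number beyond the scatter remains open. So does whether a hydroxy elsewhere on this ring, or paired with the chloro of compound 2, would do so.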